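Fluoro step on a second core: cytotoxicity notes

This account rests on a few compounds, and the source may have more. Where it says the series, first, only, none or still open, it means among the compounds named here.

Compound 1 `C=C1C(=O)[C@]23C[C@@]1(O)CC[C@H]2c1ccc(O)c(C)c1[C@@H]3Cn1cc(-c2ccccc2)nn1` and compound 2 `C=C1C(=O)[C@]23C[C@@]1(O)CC[C@H]2c1ccc(O)c(C)c1[C@@H]3Cn1cc(-c2ccc(F)cc2)nn1` share one core; compound 3 `C=C1C[C@]23C[C@@]1(O)CC[C@H]2c1cc(Br)c(O)c(C)c1[C@@H]3Cn1cc(-c2ccccc2)nn1` and compound 4 `C=C1C[C@]23C[C@@]1(O)CC[C@H]2c1cc(Br)c(O)c(C)c1[C@@H]3Cn1cc(-c2ccc(F)cc2)nn1` share another, and the difference between the two cores is not broken down here. In a functional assay on A549 cells (Homo sapiens) for cytotoxicity, read by MTT assay, with a stated time of 4 days (on this read-out lower numbers stand for stronger inhibition and higher numbers for weaker inhibition), compound 1 gives 1160 nM. In this assay compound 2 gives 940 nM. The change between them, (fluoro in place of hydrogen on an aromatic carbon), made a step of a 1.2-fold lower number from compound 1 to compound 2 (0.09 log units; within the scatter). For compound 3 the result in this assay is a limit of the assay, > 20000 nM, which is the limit of > 20000 nM in this assay, at which 1 of the 3 values shown sits. Compound 4 carries the same kind of change against compound 3, (fluoro in place of hydrogen on an aromatic carbon), and the two place descriptions read alike word for word. The step from compound 3 to compound 4 in this assay is expected to be small, a step that the limit leaves unreadable from compound 3 to compound 4, because the measured step of a 1.2-fold lower number from compound 1 to compound 2 (0.09 log units; within the scatter) was within the scatter. Compound 4 is therefore expected to give about 25000 nM in this assay, most likely again reported only as a limit, with an estimated range from 10000 nM to 60000 nM.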

Compound 4, half-maximal inhibitory concentration: 17900 nM
Compound 4: the middle estimate sits 1.4-fold (0.15 log units) above what was measured, within the range that was stated.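

In this assay, phenyl to 4-fluorophenyl on the second core gives an at least 1.1-fold lower number from compound 3 to compound 4 (0.04 log units; that floor lies within the scatter), and set beside the first core the two steps read: the same change on two cores in this assay, a 1.2-fold lower number (0.09 log units; within the scatter) from compound 1 to compound 2 and an at least 1.1-fold lower number (0.04 log units; that floor lies within the scatter) from compound 3 to compound 4; the limit leaves it open whether they differ. Among these compounds, this shows that the fluoro change, carried to the second core, gives no step that can be read as lying beyond the scatter, which fits the small step on the first core but does not establish that the step transfers with the same size. The step on the second core remains only a floor, since compound 3 is reported as a limit of the assay and not as a number: the limit of > 20000 nM in this assay, at which 1 of the 4 values shown sits.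

On these data alone, whether a different group on the same aromatic carbon, such as a methoxy group, an amine or a carboxylic acid, would move the number beyond the scatter on either core remains open. The compounds shown also leave open how much of the difference between the two cores comes from the carbonyl and how much from the bromo group.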